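The source may report more compounds than this note shows. Statements on the series, on what has been measured and on what is new or still open speak of the compounds shown alone.

Compound 2 `CCCCOc1ccc(-c2nc3ncccn3c2N)cc1` gives only a limit in a toxicity assay on A549 cells (Homo sapiens) for cytotoxicity, read by luminescence and CellTiter-Glo, with a stated time of 48 h (a lower number here means that less compound is tolerated, a higher number that more compound is tolerated), namely > 100000 nM. Compound 1 `CCCCOc1ccc(-c2nc3ncccn3c2NCCC)cc1` likewise sits at a limit in this assay, at > 100000 nM. The step that the two limits leave unreadable from compound 1 to compound 2 is thus unreadable, both values resting on (the limit of > 100000 nM in this assay, at which 2 of the 2 values shown sit). Compound 3 `Nc1c(-c2ccc(Br)cc2)nc2ncccn12` differs from compound 2 by bromo in place of butoxy on an aromatic carbon. For the measured compounds named here, no measured step bears on a change at this position, and neither measured compound returns a number inside the range, so no step beyond the scatter is expected and a limit is again the likeliest outcome. Compound 3 is estimated at 100000 nM, between 30000 nM and 300000 nM. This corresponds to an expected step of a number no higher from compound 2 to compound 3 (the limit leaves the size open).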

Compound 3, half-maximal cytotoxic concentration: > 100000 nM
Compound 3: a limit, no number; the forecaster's own chance of this, stated with the estimate: 70%; the middle value sits exactly at the limit.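

No step can be read from compound 2 to compound 3, as both values are limits: the limit of > 100000 nM in this assay, at which 3 of the 3 values shown sit.

The compounds shown leave open whether any change on the shared core gives a number within the range of this assay at all.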